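Methyl to fluoro on the carbonyl-side ring

The source may report more compounds than this note shows. Statements on the series, on what has been measured and on what is new or still open speak of the compounds shown alone.

Within the data shown here, compound 2, `COc1cc(OC)c(OC)cc1/C=C/C(=O)c1ccc(C)cc1`, is the one compound with a number in a functional assay on SW982 cells (Homo sapiens) for inhibition, read by MTT assay, with a stated time of 72 h; on this read-out lower numbers stand for stronger inhibition and higher numbers for weaker inhibition: compound 2 gives 81100 nM. Compound 1, `COc1cc(OC)c(OC)cc1/C=C/C(=O)c1cc(Cl)ccc1O`, reaches only the limit of the assay, > 150000 nM, and so offers no number. Among the measured compounds shown here, the step of an at least 1.8-fold lower number from compound 1 to compound 2 (0.26 log units; that floor lies within the scatter) is the single measured step, and its floor sits within the scatter, so it shows little on its own; it also concerns a different change than the one now at hand. Compound 3, `COc1cc(OC)c(OC)cc1/C=C/C(=O)c1ccc(F)cc1`, differs from compound 2 in one place: fluoro in place of methyl on an aromatic carbon. For the measured compounds named here, no measured step touches this change, so no move beyond the scatter is expected in this assay. The estimated step of a 1.0-fold lower number from compound 2 to compound 3 (0.01 log units; within the scatter) is expected to stay within the scatter. Compound 3 is therefore expected to give 80000 nM, with a range from 40000 nM to 160000 nM.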

Compound 3, half-maximal inhibitory concentration: 32500 nM
Compound 3: the middle estimate sits 2.5-fold (0.39 log units) above what was measured, and the stated range ends above it.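

In this assay, fluoro in place of methyl gives a 2.5-fold lower number from compound 2 to compound 3 (0.40 log units; beyond the scatter), so a swap of one atom on an aromatic carbon, para to a large group, moves the read-out beyond the scatter, though only modestly. Replacing 5-chloro-2-hydroxyphenyl with 4-fluorophenyl gives an at least 4.6-fold lower number from compound 1 to compound 3 (0.66 log units; beyond the scatter), whereas the earlier step to 4-methylphenyl had a floor within the scatter. Compound 1 stands at a limit, so this new step is also only a floor: the limit of > 150000 nM in this assay, at which 1 of the 3 values shown sits.

The compounds shown leave open whether a chloro group, a methoxy group, an amine or a carboxylic acid at this same place would lower the number further or raise it again. With only methyl and fluoro to compare here, they also cannot say why the swap lowers the number.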